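Lengthening the hydroxamate linker of compound 2 by one carbon

The source may report more compounds than this note shows. Statements on the series, on what has been measured and on what is new or still open speak of the compounds shown alone.

The series shares a resorcinol-type core carrying an isopropyl group and an amide to an aniline that bears a hydroxamic acid chain. Compound 2, `CC(C)c1cc(C(=O)N(C)c2ccc(NC(=O)CCCCCCCC(=O)NO)cc2)c(O)cc1O`, gives 1060 nM in a functional assay on HCT-116 cells (Homo sapiens) for inhibition, read by sulforhodamine B assay, with a stated time of 48 h; on this read-out higher numbers stand for weaker inhibition of growth and lower numbers for stronger inhibition of growth. That is the lowest of the two numbers recorded; compound 3, `CC(C)c1cc(C(=O)Nc2ccccc2NC(=O)CCCCCCC(=O)NO)c(O)cc1O`, gives 4920 nM in this assay, a gap beyond the usual scatter. Compound 1, `CC(C)c1cc(C(=O)N(c2ccc(NC(=O)CCCCCCC(=O)NO)cc2)C(C)C)c(O)cc1O`, reaches only the limit of > 10000 nM in this assay, a limit rather than a number (the limit of > 10000 nM in this assay, at which 1 of the 3 values shown sits).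

Compound 4, `CC(C)c1cc(C(=O)N(C)c2ccc(NC(=O)CCCCCCCCC(=O)NO)cc2)c(O)cc1O`, has not been measured. It differs from compound 2 in one place: (hydroxycarbamoyl)methyl in place of hydroxycarbamoyl on a saturated chain carbon, seven bonds along the chain from a carbonyl carbon. For the measured compounds named here, with no measured pair of compounds differing only in chain length, the size of this step in this assay is open; a modest shift in either direction, or none beyond the scatter, seems possible. Compound 4 is therefore expected to give about 1500 nM in this assay, between 500 nM and 5000 nM, a step of a 1.4-fold higher number from compound 2 to compound 4 (0.15 log units; within the scatter).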

Compound 4, concentration for 50% growth inhibition: 590 nM
Estimate against measurement, compound 4: 2.5-fold (0.41 log units) above, and the stated range covers the measured number.
By their numbers in this assay, from the lowest: compounds 4 and 2 (each within the scatter of the next); then compound 3. At a limit, above all of these: compound 1.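

For the compounds shown here, this pair is the first to differ in one place only, and it isolates the chain length. In this assay, (hydroxycarbamoyl)methyl in place of hydroxycarbamoyl, on a saturated chain carbon seven bonds along the chain from a carbonyl carbon, gives a 1.8-fold lower number from compound 2 to compound 4 (0.25 log units; within the scatter), so this position accepts the extra carbon and compound 2 and compound 4 cannot be told apart. Nothing measured here offers a cause for this result.

The compounds shown leave open whether a longer chain, such as 3-(hydroxycarbamoyl)propyl, would stay within the scatter of compound 4. They also leave open what a carboxylic acid in place of hydroxycarbamoyl would give, and compound 1 and compound 3 differ from compound 2 in more than one place, so they cannot settle either question.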